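The source may report more compounds than this note shows. Statements on the series, on what has been measured and on what is new or still open speak of the compounds shown alone.

Measured compounds in the series:

compound 1, `CC(O)(CS(=O)(=O)c1ccc(S(F)(F)(F)(F)F)cc1)C(=O)Nc1ccc(C#N)cc1C(F)(F)F`, 25600 nM
compound 2, `CC(O)(CS(=O)(=O)c1ccc(S(F)(F)(F)(F)F)cc1)C(=O)Nc1ccc([N+](=O)[O-])cc1C(F)(F)F`, 17700 nM
compound 3, `CC1(C)C(=O)N(c2ccc(C#N)cc2C(F)(F)F)C(=S)N1c1cccc(S(F)(F)(F)(F)F)c1`, 100000 nM

All three were run in a functional assay on DU-145 cells (Homo sapiens) for antiproliferative activity, read by propidium iodide staining, with a stated time of 96 h; on this read-out higher numbers stand for weaker inhibition and lower numbers for stronger inhibition. Compound 1 and compound 2 share one core and differ only by nitro in place of cyano on an aromatic carbon; the step of a 1.4-fold lower number from compound 1 to compound 2 (0.16 log units; within the scatter) is small and stays inside the scatter of the method. Compound 3 carries a different core, and how its core differs from that of compound 1 is not broken down here. Compound 3 gives the highest number of the three, with compound 1 the nearest and compound 2 the furthest, both gaps being beyond the scatter.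

Compound 4, `CC1(C)C(=O)N(c2ccc([N+](=O)[O-])cc2C(F)(F)F)C(=S)N1c1cccc(S(F)(F)(F)(F)F)c1`, is not yet measured. It differs from compound 3 by nitro in place of cyano on an aromatic carbon, the same change as that from compound 1 to compound 2. The expected step in this assay is a 1.4-fold lower number from compound 3 to compound 4 (0.15 log units; within the scatter), resting on the small step of a 1.4-fold lower number from compound 1 to compound 2 (0.16 log units; within the scatter) seen on the other core; whether that step carries over to this core is not known. The estimated value for compound 4 is 70000 nM, with a range from 25000 nM to 150000 nM.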

Compound 4, half-maximal inhibitory concentration: 100000 nM
Compound 4: middle estimate off by 1.4-fold (0.15 log units), on the low side; low and high end bracket the measured number.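

In this assay, nitro in place of cyano on an aromatic carbon of the second core gives no change at the digits printed from compound 3 to compound 4 (within the scatter). Set beside the step on the first core, the result shows no difference in how this change behaves on the two cores: the same change on two cores in this assay, a 1.4-fold lower number (0.16 log units; within the scatter) from compound 1 to compound 2 and no change at the digits printed (within the scatter) from compound 3 to compound 4, 1.4-fold (0.16 log units) apart, within the scatter of two such steps

This agreement supports only a limited statement: in these two pairs, the swap leaves the number inside the scatter on both cores, but neither step is large enough to show that a real effect of the change carries from one core to the other, and two cores say nothing about further cores or other read-outs.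

The compounds shown leave open whether another group in place of cyano on that aromatic carbon, such as an amine or a carboxylic acid, would move the number beyond the scatter on either core. Also open, going by these compounds, is what replacing the trifluoromethyl group with a simple methyl group would do on each core.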